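An Isomeric Swap on the Ring Amine of Compound 1

The compounds below may be only part of what the source reports. "The series", "measured", "known", "first", "only" and "open" are said of these compounds alone.

In a physicochemical assay for lipophilicity, read by HPLC, measured as chromatographic lipophilicity, at pH 7.4 (on this read-out higher numbers stand for higher lipophilicity and lower numbers for lower lipophilicity), compound 1 (`N#Cc1cnc(N2CCC(C(=O)N3N=CC[C@H]3c3cc(F)cc(F)c3)CC2)cn1`) gives 5.2 and compound 2 (`CC(C)(C)C(=O)N1N=CCC1c1c[nH]cn1`) gives 1.7 on the same read-out. Compound 1 therefore stands the higher of the two, and the gap between them lies beyond the scatter of such measurements. Going by the values given here, no two measured compounds differ in one place only, so no measured step yet speaks directly to a single structural change.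

Compound 3 (`N#Cc1nccc(N2CCC(C(=O)N3N=CC[C@H]3c3cc(F)cc(F)c3)CC2)n1`) has the same atoms as compound 1, joined differently. In it, 2-cyanopyrimidin-4-yl takes the place of 5-cyanopyrazin-2-yl on an amine nitrogen in a ring (2-cyanopyrimidin-4-yl in place of 5-cyanopyrazin-2-yl on an amine nitrogen in a ring). All else is kept, so the value of compound 1 at 5.2 serves as the anchor for the expectation. In this assay the expected change is small and slightly downward, an estimated a number 0.20 log units lower from compound 1 to compound 3 (within the scatter) that would stay within the scatter. For compound 3 the estimated value is 5 with an expected range from 4.6 to 5.4 on this read-out.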

Compound 3, distribution coefficient: 5.1
Compound 3: the middle estimate sits 0.10 log units below what was measured, within the range that was stated.
By their numbers in this assay, from the lowest: compound 2; then compounds 3 and 1 (each within the scatter of the next).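

On the amine nitrogen in a ring, putting 2-cyanopyrimidin-4-yl in place of 5-cyanopyrazin-2-yl gives, in this assay, a number 0.10 log units lower from compound 1 to compound 3 (within the scatter). Going by these compounds alone, this is the first measured step that differs in one place, so this position can now be read directly, which compounds 1 and 2, differing in more than one place, did not allow. The two groups have the same atoms, joined differently, and on this read-out this rearrangement does not separate compound 3 from compound 1, though no measurement shown offers any explanation for that outcome.

What stays open is whether this position tolerates change only among these two nitrile-bearing aromatic rings, or whether a plain phenyl ring or an acetyl group on the same amine nitrogen would also leave the number within the scatter. The compounds shown also leave open whether the same swap would read alike if chlorine atoms stood in place of the fluorine atoms elsewhere in the core of compound 1.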